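Adding trimethoxyphenyl to a weakly growth-inhibiting compound

This account rests on a few compounds, and the source may have more. Where it says the series, first, only, none or still open, it means among the compounds named here.

In a functional assay on HCT-116 cells (Homo sapiens) for inhibition, read by sulforhodamine B assay, with a stated time of 48 h, tested at 50 uM (on this read-out higher numbers stand for more inhibition of growth at the one concentration tested and lower numbers for less inhibition of growth), compound 1 (`COc1cc(/C=C/C(=O)/C=C/c2cccs2)ccc1OCc1cn(CCOc2cc(=O)oc3ccccc23)nn1`) gives 71% and stands beyond the scatter above compound 2 (`COc1cc(/C=C/C(=O)/C=C/c2ccccc2)ccc1OCc1cn(CCCCOc2cc(=O)oc3ccccc23)nn1`), which gives 34% in the same test. That value lies within the scatter of compound 3 (`COc1cc(/C=C/C(=O)/C=C/c2cccs2)ccc1OCc1cn(CCCCCOc2cc(=O)oc3ccccc23)nn1`), which gives 31% on this read-out. Compound 4 (`COc1cc(/C=C/C(=O)/C=C/c2cc(OC)c(OC)c(OC)c2)ccc1OCc1cn(CCCCOc2cc(=O)oc3ccccc23)nn1`) departs from compound 2 by a single change (3,4,5-trimethoxyphenyl in place of phenyl on a double-bonded chain carbon bound to a double-bonded chain carbon). For the measured compounds named here, no measured pair differs in one place only, so the data offer no direct guide to this change. In this assay no step beyond the scatter is therefore expected, with a slight upward drift at most. The estimate is a number 4 percentage points higher from compound 2 to compound 4 (within the scatter) on this read-out. Compound 4 is expected at 38% with an estimated range of 22% to 58% of growth inhibition.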

Compound 4, percent growth inhibition at one concentration: 63%
For compound 4 the middle estimate is 25 percentage points below the measured one; the whole stated range lies below it.
By their numbers in this assay, from the lowest: compounds 3 and 2 (each within the scatter of the next); then compounds 4 and 1 (each within the scatter of the next).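

In this assay, the change to 3,4,5-trimethoxyphenyl in place of phenyl gives a number 29 percentage points higher from compound 2 to compound 4 (beyond the scatter). For the compounds shown here, this is the first step between compounds that differ in one place, and it shows that growth inhibition responds to the group on a double-bonded chain carbon bound to a double-bonded chain carbon. Nothing measured here speaks to what lies behind this step.

The compounds shown leave open whether a single methoxy group, an amine or a carboxylic acid on that phenyl would give a similar step. They also leave open whether the same change would carry over to compound 1 or compound 3.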